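Swapping the aryl on sulfur: fluorophenyl to naphthyl

The compounds below may be only part of what the source reports. "The series", "measured", "known", "first", "only" and "open" are said of these compounds alone.

Of the compounds shown here, three sharing one core have been measured. In a functional assay on SMMC-7721 cells (Homo sapiens) for inhibition, read by CCK-8 assay, with a stated time of 72 h, tested at 8 uM (on this read-out higher numbers stand for more inhibition of growth at the one concentration tested and lower numbers for less inhibition of growth), compound 1 `Cc1ccc(SCc2ccc(/C=C/C(=O)Nc3ccccc3N)cc2)cc1` gives 22.2%, compound 2 `Nc1ccccc1NC(=O)/C=C/c1ccc(CSc2ccc(F)cc2)cc1` gives 15.4%, and compound 3 `Nc1ccccc1NC(=O)/C=C/c1ccc(CSc2cccc(F)c2)cc1` gives 8.25%, the lowest of the three numbers, with the gap to compound 2 inside the scatter and the gap to compound 1 beyond it.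

Compound 4 `Nc1ccccc1NC(=O)/C=C/c1ccc(CSc2cccc3ccccc23)cc1` has not yet been tested; it differs from compound 3 as follows: naphthalen-1-yl in place of 3-fluorophenyl on a sulfur.

Within the data shown here, the steps that bear on this all change the group on that sulfur. The step of a number 14 percentage points lower from compound 1 to compound 3 (beyond the scatter) and the step of a number 7.2 percentage points lower from compound 2 to compound 3 (within the scatter) show that such swaps move the number only a little. Among the measured compounds shown here, no measured step covers a naphthalene ring, so the expected step of a number 6.8 percentage points higher from compound 3 to compound 4 (within the scatter) is small. Compound 4 is estimated at 15%, within 2% to 35%.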

Compound 4, percent growth inhibition at one concentration: 18.3%
The estimate for compound 4 lay 3.3 percentage points below the measured number, and the stated range covers the measured number.
By their numbers in this assay, from the lowest: compounds 3, 2, 4 and 1 (each within the scatter of the next, the first and the last beyond it).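

On this sulfur, a larger group is accepted: naphthalen-1-yl, with 10 heavy atoms against 7 in 3-fluorophenyl, gives a number 10.1 percentage points higher from compound 3 to compound 4 (beyond the scatter) and so does not lower the number. Against the other two groups it gives a number 2.9 percentage points higher from compound 2 to compound 4 (within the scatter) and a number 3.9 percentage points lower from compound 1 to compound 4 (within the scatter) and thus sits level with 4-fluorophenyl and 4-methylphenyl. Nothing available here accounts for these differences.

Still open, going by these compounds, is how an amine or a carboxylic acid on the aromatic ring would read. So is the effect of a non-aromatic cyclohexyl group on the sulfur.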